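Swapping the methoxypyridine for a fluoropyridine

The compounds below may be only part of what the source reports. "The series", "measured", "known", "first", "only" and "open" are said of these compounds alone.

Measured so far:
compound 1 `COc1ccnc(Nc2cc3[nH]c(-c4cccc(C(F)(F)F)c4)nc3cn2)c1` with 62%
compound 2 `FC(F)(F)c1cccc(-c2nc3cnc(Nc4ccncn4)cc3[nH]2)c1` with 89%
compound 3 `Fc1ccc(-c2nc3cnc(Nc4ccccn4)cc3[nH]2)cc1F` with 7.5%

In an ADME assay on microsomes from liver (Mus musculus) for metabolic stability, read by LC-MS, with a stated time of 30 min, tested at 0.1 uM (a lower number here means that less of the compound is left, a higher number that more of the compound is left), compound 1 gives 62%, which places it second highest of the three numbers. Compound 2 sits nearest, and the step of a number 27 percentage points higher from compound 1 to compound 2 (beyond the scatter) is a modest gain that lies beyond the scatter. Compound 3 is furthest from compound 1; it differs from compound 1 in two places at once, so its low value cannot be tied to a single change.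

Compound 4 `Fc1ccc(Nc2cc3[nH]c(-c4cccc(C(F)(F)F)c4)nc3cn2)nc1` has not yet been measured. It differs from compound 1 in one place: 5-fluoropyridin-2-yl in place of 4-methoxypyridin-2-yl on a nitrogen on an aromatic ring. Among the measured compounds shown here, the only measured step that touches this same position is the one from compound 1 to compound 2, where a different aromatic ring on the same nitrogen raised the number by a modest amount. That step changed the ring itself, whereas here the ring stays a pyridine and only its substituent changes, so the comparison is loose.

The expectation for compound 4 is therefore a number close to that of compound 1, with the step of a number 3 percentage points higher from compound 1 to compound 4 (within the scatter) expected to stay within the scatter. Compound 4 is estimated at 65%, in a range from 40% to 88%.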

Compound 4, percent of the compound remaining: 54%
For compound 4 the middle estimate is 11 percentage points above the measured one; the measured number falls inside the stated range.
By their numbers in this assay, from the lowest: compound 3; then compounds 4 and 1 (each within the scatter of the next); then compound 2.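

In this assay, putting 5-fluoropyridin-2-yl in place of 4-methoxypyridin-2-yl on the nitrogen gives a number 8 percentage points lower from compound 1 to compound 4 (within the scatter), so this assay cannot tell these two substituted pyridines apart. Among the compounds shown here, the earlier compounds offered only one comparison at this position, which changed the ring and its substituent together; this pair keeps a pyridine and changes only the substituent and where it sits. For the compounds shown here, replacing pyrimidin-4-yl with 5-fluoropyridin-2-yl gives a number 35 percentage points lower from compound 2 to compound 4 (beyond the scatter), so among the three compounds sharing the trifluoromethyl-bearing side of the molecule, both pyridines now stand apart from the pyrimidine, and no compound among those three goes against this.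

From the compounds shown here alone, it remains open whether a pyridine carrying a nitrile or a dimethylamino group would stay with these two pyridines or move towards pyrimidin-4-yl, and whether the same gap would appear with a different aromatic ring on the other side of the core. Why the pyrimidine compound keeps more of its material also stays unexplained, as no supporting measurement bears on this result.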